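Butoxy to Phenyl: What to Expect for Compound 4

The source may report more compounds than this note shows. Statements on the series, on what has been measured and on what is new or still open speak of the compounds shown alone.

Compound 2 `CCCCOc1ccc(C(=O)NNc2c(Br)cccc2Br)cc1` is one of three members of the shared core whose toxicity toward dog kidney cells has been measured in a toxicity assay on MDCK cells (Canis lupus familiaris) for cytotoxicity, read by CCK-8 assay, with a stated time of 48 h; on this read-out lower numbers stand for higher toxicity in this test and higher numbers for lower toxicity in this test. Compound 2 gives > 100000 nM, which is a limit of the assay and not a number. Compound 1 `CCOc1ccc(C(=O)NNc2c(Br)cccc2Br)cc1` likewise gives > 100000 nM, a limit. Compound 3 `O=C(NNc1c(Br)cccc1Br)c1cccnc1` gives > 100000 nM, again a limit. Among the compounds with values here, the only step between two measured compounds that differ in one place, a step that the two limits leave unreadable from compound 1 to compound 2, is therefore unreadable, because both of its ends rest on (the limit of > 100000 nM in this assay, at which 3 of the 3 values shown sit). Compound 4 `O=C(NNc1c(Br)cccc1Br)c1ccc(-c2ccccc2)cc1` has not yet been measured; it differs from compound 2 by phenyl in place of butoxy on an aromatic carbon. Within the data shown here, no measured step bears on a phenyl entering in place of butoxy, and with every value shown sitting at the same limit there is no readable step of any size to build on. The step is expected to be a step that the limit leaves unreadable from compound 2 to compound 4, nothing beyond the scatter. Compound 4 is therefore estimated at 150000 nM, ranging from 50000 nM to 500000 nM, and most likely reported once more only as a limit.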

Compound 4, half-maximal cytotoxic concentration: 84100 nM
Compound 4: middle estimate off by 1.8-fold (0.25 log units), on the high side; low and high end bracket the measured number.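

Within the data shown here, compound 4 is the first compound of the shared core to give a readable number rather than a limit in this assay, with phenyl on an aromatic carbon para to a large group. Phenyl in place of butoxy gives an at least 1.1-fold lower number from compound 2 to compound 4 (0.07 log units; that floor lies within the scatter), and phenyl in place of ethoxy gives an at least 1.1-fold lower number from compound 1 to compound 4 (0.07 log units; that floor lies within the scatter). Both figures are floors rather than sizes, and neither establishes a change beyond the scatter, because the other end of each step rests on a limit: the limit of > 100000 nM in this assay, at which 3 of the 4 values shown sit.

As far as these compounds go, the true size of both steps stays open. So does whether the readable number goes with the aromatic ring itself, which a cyclohexyl group or a longer chain on the same carbon could test, and what an amine or a carboxylic acid on the entering phenyl would do.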